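This account rests on a few compounds, and the source may have more. Where it says the series, first, only, none or still open, it means among the compounds named here.

Of the compounds shown here, three built on similar cores have been tested so far in a functional assay on T-24 cells (Homo sapiens) for cytotoxicity, read by colorimetric assay and MTT assay; a higher number here means a weaker inhibitor, a lower number a stronger inhibitor. Compound 1 `COc1ccc2cc(-c3ccccc3)c(O)nc2c1` gives 10000 nM, and compound 2 `COc1ccc(-c2cc3cccc(OC)c3nc2O)cc1` gives 10000 nM. Compound 3 `CCOC(=O)Cn1c(=O)c(-c2ccc(OC)cc2)cc2c(OC)cc(OC)cc21` gives 10000 nM, which puts it level with compound 1 and compound 2, with nothing to separate the three.

Compound 4 `COc1ccc(-c2cc3c(OC)cc(OC)cc3n(CCC#N)c2=O)cc1` has not yet been measured. It differs from compound 3 in one place, and the change is cyanomethyl in place of ethoxycarbonyl on a saturated chain carbon bound to an aromatic nitrogen. In words, cyanomethyl stands in place of ethoxycarbonyl on a saturated chain carbon bound to an aromatic nitrogen.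

For the measured compounds named here, no two measured compounds differ in just one place, so the data give no direct guide to the size of such a change. Because compound 3 gives 10000 nM and sits level with both of the others, no step beyond the scatter is expected in this assay, in either direction. The expected change, no change at the digits printed from compound 3 to compound 4 (within the scatter), is therefore small. For compound 4 the estimated value is 10000 nM, with an expected range of 4000 nM to 20000 nM.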

Compound 4, half-maximal inhibitory concentration: 10000 nM
For compound 4 middle estimate and measured number coincide at the digits printed; low and high end bracket the measured number.
By their numbers in this assay, from the lowest: compounds 1, 2, 3 and 4 (each within the scatter of the next).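

For the compounds shown here, measured in this assay on a saturated chain carbon bound to an aromatic nitrogen, cyanomethyl in place of ethoxycarbonyl gives no change at the digits printed from compound 3 to compound 4 (within the scatter) and this is the first direct reading of a change in one place. Here, a group of 5 heavy atoms with a double bond gives way to one of 3 heavy atoms with a triple bond, and the read-out does not separate the pair. No measurement at hand explains this result.

What the compounds shown leave open is whether any group at this position can bring a value apart from that of compound 3. An amine, a carboxylic acid or a longer chain in that place would test this.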